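The source may report more compounds than this note shows. Statements on the series, on what has been measured and on what is new or still open speak of the compounds shown alone.

Compound 1 `O=C(CCN1CCN(c2ccc(CO)c(Cl)c2)CC1)c1ccc(Cl)cc1` gives 60 nM in an assay on CHO cells for binding affinity to D(4) dopamine receptor (Homo sapiens); on this read-out higher numbers stand for weaker inhibition and lower numbers for stronger inhibition.
Compound 2 `Cc1ccc(C2CCN(CCC3NC(=O)c4ccccc43)CC2)cc1C` gives 9.3 nM.
Compound 3 `Cc1ccnc(N2CCN(CCC3NC(=O)c4ccccc43)CC2)c1` gives 22.6 nM.

Among these three numbers compound 3 stands second highest: compound 2 shows a lower number and compound 1 a higher one, and both gaps lie beyond the usual scatter. Compound 4 `COc1ccc(N2CCN(CCC3NC(=O)c4ccccc43)CC2)cc1` differs from compound 3 in one place, (4-methoxyphenyl in place of 4-methylpyridin-2-yl on an amine nitrogen in a ring), that is, 4-methoxyphenyl in place of 4-methylpyridin-2-yl on an amine nitrogen in a ring. Among the compounds with values here, no two of the measured compounds differ in a single place, so there is no measured step of this kind to lean on. The step from a 1.5-fold lower number from compound 3 to compound 4 (0.18 log units; within the scatter) is expected to be small, toward a lower number, and probably not beyond the scatter. Compound 4 is therefore estimated at 15 nM, with a range from 4 nM to 60 nM in this assay.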

Compound 4, inhibition constant: 37.3 nM
Beside the measured number, compound 4's estimate is 2.5-fold (0.40 log units) below it; low and high end bracket the measured number.
By their numbers in this assay, from the lowest: compound 2; then compounds 3, 4 and 1 (each within the scatter of the next, the first and the last beyond it).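

In this assay, the swap of 4-methylpyridin-2-yl for 4-methoxyphenyl on the amine nitrogen in the ring gives a 1.7-fold higher number from compound 3 to compound 4 (0.22 log units; within the scatter), the first single-place step among these compounds. At this position, the assay therefore does not separate an aromatic ring with one hetero atom from one of carbon only, at least for these two groups. Nothing available explains this result.

The compounds shown leave open whether a plain phenyl or a pyrimidin-2-yl group on that nitrogen would read the same. They also leave open whether a carboxylic acid on the aromatic ring would shift the number beyond the scatter.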